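Replacing the distal aryl group: notes toward compound 4

The source may report more compounds than this note shows. Statements on the series, on what has been measured and on what is new or still open speak of the compounds shown alone.

Measured so far:
compound 1, `Cc1n[nH]c(C(=O)O)c1Cc1ccc(Oc2ccccc2)cc1`, gives 43% in an assay on isolated protein for inhibition of 2-Hydroxyacid oxidase 2 (Homo sapiens), tested at 10 uM; a lower number here means a weaker effect, a higher number a stronger effect of the compound at the concentration tested
compound 2, `Cc1n[nH]c(C(=O)O)c1Cc1ccc(C#N)cc1`, gives 6% in this assay
compound 3, `Cc1n[nH]c(C(=O)O)c1Cc1ccc(-c2ccc(F)cc2)cc1`, gives 25% in this assay

Compound 3 stands second of the three in this assay: compound 1 lies higher, by a number 18 percentage points lower from compound 1 to compound 3 (beyond the scatter), and compound 2 lies lower, by a number 19 percentage points higher from compound 2 to compound 3 (beyond the scatter). Both gaps are beyond the scatter.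

The next compound, compound 4, `Cc1n[nH]c(C(=O)O)c1Cc1ccc(C(=O)O)cc1`, has not been measured in this assay. It differs from compound 3 in one place: carboxy in place of 4-fluorophenyl on an aromatic carbon.

Among the compounds with values here, the steps that bear on this change are those that swap the group on the same aromatic carbon. Going from the phenoxy group to the small cyano group gave a number 37 percentage points lower from compound 1 to compound 2 (beyond the scatter); going from the cyano group to the 4-fluorophenyl group gave a number 19 percentage points higher from compound 2 to compound 3 (beyond the scatter). In both cases the smaller group without a ring came out lower. Carboxy is likewise a small group without a ring, so for compound 4 a lower number in this assay is expected, of a size near a number 17 percentage points lower from compound 3 to compound 4 (beyond the scatter). The estimate for compound 4 is 8%, with a range from 0% to 25%.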

Compound 4, a percentage reported as inhibition, at one concentration (the size of the read-out at that concentration, not a potency): 22%
The estimate for compound 4 lay 14 percentage points below the measured number; the measured number falls inside the stated range.
By their numbers in this assay, from the lowest: compound 2; then compounds 4 and 3 (each within the scatter of the next); then compound 1.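

In this assay, carboxy in place of 4-fluorophenyl gives a number 3 percentage points lower from compound 3 to compound 4 (within the scatter) on this aromatic carbon, so the earlier match between a group without a ring and a lower number fails for carboxy. The two groups without a ring also differ from each other, since carboxy in place of cyano gives a number 16 percentage points higher from compound 2 to compound 4 (beyond the scatter) and the absence of a ring therefore does not set the number by itself, while carboxy in place of phenoxy gives a number 21 percentage points lower from compound 1 to compound 4 (beyond the scatter) and phenoxy keeps the highest number of the four. Nothing available explains the difference between carboxy and cyano.

From the compounds shown here alone, whether a methyl ester or a primary amide would match carboxy remains open. So does the effect of a longer chain ending in a carboxylic acid at this position.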